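Acetamido in Place of Methyl: Paw Edema Inhibition

A few compounds are considered here, and "the series" means these few. Any claim that something is new, unique, unknown or untested is made for them only; others in the source may bear on it.

Measured compounds:
compound 1, `Cc1nc2ccccc2c(=O)n1NS(=O)(=O)c1ccccc1`, 22.2%
compound 2, `Cc1ccc(S(=O)(=O)Nn2c(C)nc3ccccc3c2=O)cc1`, 24.2%

Both compounds were tested in a functional assay on the whole organism (strain Sprague-Dawley) for inhibition, with Rattus norvegicus as the target, read by paw edema, with stated times of 30 min and 2 h, at a dose of 80 mg/kg by the oral route; on this read-out lower numbers stand for less inhibition and higher numbers for more inhibition at the one dose given (going by the name of the read-out). Compound 1 gives 22.2%, and compound 2 gives 24.2%. Of the two numbers compound 2 carries the higher one, but the step of a number 2 percentage points higher from compound 1 to compound 2 (within the scatter) lies within the scatter, so the two compounds cannot be ranked against each other on this read-out.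

Compound 3, `CC(=O)Nc1ccc(S(=O)(=O)Nn2c(C)nc3ccccc3c2=O)cc1`, has not yet been measured. It differs from compound 2 by acetamido in place of methyl on an aromatic carbon.

Among the compounds with values here, only one measured step exists, and it concerns a different exchange on the same kind of aromatic carbon: methyl in place of hydrogen, with a number 2 percentage points higher from compound 1 to compound 2 (within the scatter), which was within the scatter. Within the data shown here, no measured pair shows acetamido entering anywhere, so there is no direct precedent for this change. On the single step shown, the expectation for compound 3 is a step of a number 1.8 percentage points higher from compound 2 to compound 3 (within the scatter), that is, no movement beyond the scatter in either direction. Compound 3 is therefore estimated at 26%, with a range from 12% to 40%.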

Compound 3, a percentage reported as inhibition, in the whole organism at one dose (the size of the read-out at that dose, not a potency): 37.4%
The estimate for compound 3 lay 11.4 percentage points below the measured number; measured number inside the range.
By their numbers in this assay, from the lowest: compounds 1 and 2 (each within the scatter of the next); then compound 3.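

The aromatic carbon para to a large group, which gave no readable change with methyl in place of hydrogen, proves responsive in this assay once acetamido stands there. Acetamido in place of methyl gives a number 13.2 percentage points higher from compound 2 to compound 3 (beyond the scatter) and acetamido in place of hydrogen gives a number 15.2 percentage points higher from compound 1 to compound 3 (beyond the scatter) on the same shared core, so this exchange moves the number beyond the scatter whichever of the two smaller substituents it replaces, and compound 3 stands clear of both compound 1 and compound 2. Nothing measured here offers an explanation for this difference.

The compounds shown leave open whether the gain belongs to the amide specifically or would come with any larger group on this carbon, and an amine, a methoxy group or an amide with a longer chain in the same place would bear on that question. They also leave open whether the order of the three compounds would hold at any other dose, since the read-out rests on a single oral dose.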